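The source may report more compounds than this note shows. Statements on the series, on what has been measured and on what is new or still open speak of the compounds shown alone.

Measured so far in an ADME assay for permeability, using PAMPA, at pH 4; on this read-out higher numbers stand for higher permeability and lower numbers for lower permeability:
- compound 1 `COc1ccc2c(=O)c(Cc3ccccc3)c(C)[nH]c2c1` gives 200 10^-6 cm/s.
- compound 2 `Cc1[nH]c2cc(Cl)ccc2c(=O)c1Cc1ccccc1` gives 341 10^-6 cm/s.
- compound 3 `COc1ccc2c(c1)c(=O)c(Cc1ccccc1)c(C)n2C` gives 295 10^-6 cm/s.

Compound 2 differs from compound 1 by chloro in place of methoxy on an aromatic carbon, and that change made a 1.7-fold higher number from compound 1 to compound 2 (0.23 log units; within the scatter). Compound 3 and compound 1 share no single counted difference; the difference between the two cores is not broken down here, and their two values in this assay lie within the scatter of each other. Compound 4 `Cc1c(Cc2ccccc2)c(=O)c2cc(Cl)ccc2n1C` has not yet been measured. It differs from compound 3 by chloro in place of methoxy on an aromatic carbon, which is the same change at the same place as that from compound 1 to compound 2. For the measured compounds named here, for compound 4 a step of a 1.4-fold higher number from compound 3 to compound 4 (0.13 log units; within the scatter) in this assay is expected, resting on a 1.7-fold higher number from compound 1 to compound 2 (0.23 log units; within the scatter) as the only prior instance of this change, itself within the scatter. Compound 4 is therefore estimated at 400 10^-6 cm/s, with the likely range from 250 10^-6 cm/s to 620 10^-6 cm/s.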

Compound 4, apparent permeability: 510 10^-6 cm/s
Beside the measured number, compound 4's estimate is 1.3-fold (0.11 log units) below it; the measured number falls inside the stated range.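

In this assay, chloro in place of methoxy on an aromatic carbon gives a 1.7-fold higher number from compound 3 to compound 4 (0.24 log units; within the scatter) and reads the same on both cores: the same change on two cores in this assay, a 1.7-fold higher number (0.23 log units; within the scatter) from compound 1 to compound 2 and a 1.7-fold higher number (0.24 log units; within the scatter) from compound 3 to compound 4, 1.0-fold (0.01 log units) apart, within the scatter of two such steps. Both steps lie within the scatter, so the pair shows only that nothing separates the two cores for this change, not that the change has a real effect on the read-out. Two cores are a narrow basis, and nothing follows for other cores or for other assays.

The compounds shown compare only methoxy and chloro at this aromatic carbon. Open, going by these compounds, is whether another group there, such as an amine, a carboxylic acid or a longer alkoxy chain, would give a step beyond the scatter, and whether that step would carry between the cores.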